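Bromo to methoxy on the aryl ring of the sulfonyl core

A few compounds are considered here, and "the series" means these few. Any claim that something is new, unique, unknown or untested is made for them only; others in the source may bear on it.

Measured so far:
compound 1 `CN(C(=O)c1ccc(Br)cc1)c1ccc2[nH]c(-c3n[nH]c4ccccc34)cc2n1` gives 6110 nM
compound 2 `COc1ccc(C(=O)N(C)c2ccc3[nH]c(-c4n[nH]c5ccccc45)cc3n2)cc1` gives 29500 nM
compound 3 `CN(c1ccc2[nH]c(-c3n[nH]c4ccccc34)cc2n1)S(=O)(=O)c1ccc(Br)cc1` gives 9850 nM

All three numbers come from a functional assay on HCT-116 cells (Homo sapiens) for antiproliferative activity, read by MTT assay, with a stated time of 72 h; a higher number here means a weaker inhibitor, a lower number a stronger inhibitor. Compound 1 and compound 3 carry the same 4-bromophenyl group and differ only in the core: (4-bromophenyl)sulfonyl in place of (4-bromophenyl)carbonyl on a nitrogen on an aromatic ring. That step reads a 1.6-fold higher number from compound 1 to compound 3 (0.21 log units; within the scatter). Compound 2 carries methoxy where compound 1 carries bromo, (methoxy in place of bromo on an aromatic carbon), and that step reads a 4.8-fold higher number from compound 1 to compound 2 (0.68 log units; beyond the scatter). From compound 2 to compound 3 the number moves by a 3.0-fold lower number from compound 2 to compound 3 (0.48 log units; beyond the scatter), but two things change at once there, so that step is not read on its own.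

Compound 4 `COc1ccc(S(=O)(=O)N(C)c2ccc3[nH]c(-c4n[nH]c5ccccc45)cc3n2)cc1` is not yet measured. It differs from compound 3 as methoxy in place of bromo on an aromatic carbon. This is the same kind of change as that from compound 1 to compound 2, now made on the sulfonyl core; the place is described in the same words in both cases. Going by the values given here, only one earlier instance exists, so the expectation rests on it alone: compound 4 is expected to show a 4.3-fold higher number from compound 3 to compound 4 (0.63 log units; beyond the scatter), matching the step of a 4.8-fold higher number from compound 1 to compound 2 (0.68 log units; beyond the scatter) seen on the carbonyl core. Compound 4 is thus estimated at 42000 nM, with a range from 12000 nM to 150000 nM.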

Compound 4, half-maximal inhibitory concentration: 22400 nM
Beside the measured number, compound 4's estimate is 1.9-fold (0.27 log units) above it; measured number inside the range.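

In this assay, methoxy in place of bromo on the sulfonyl core gives a 2.3-fold higher number from compound 3 to compound 4 (0.36 log units; beyond the scatter), so the change weakens the inhibitor on this core too, in the same direction as on the carbonyl core. The size of the step also carries across, since the two steps do not differ by more than the scatter allows: the same change on two cores in this assay, a 4.8-fold higher number (0.68 log units; beyond the scatter) from compound 1 to compound 2 and a 2.3-fold higher number (0.36 log units; beyond the scatter) from compound 3 to compound 4, 2.1-fold (0.33 log units) apart, within the scatter of two such steps. This rests on one pair per core and a single change, so it shows that this swap transfers between these two cores, but not that it would transfer to any other core, nor why methoxy gives the higher number.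

Still open, from the compounds shown here alone, is whether the same transfer holds for other groups in place of bromo, such as an amine or a carboxylic acid, and whether such a group would give a lower number than bromo on either core. Also open, going by these compounds, is how the two cores compare once the methyl on the linking nitrogen gives way to a longer chain.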